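Sulfonamide in Place of tert-Butyl on a Biphenyl Tail

A few compounds are considered here, and "the series" means these few. Any claim that something is new, unique, unknown or untested is made for them only; others in the source may bear on it.

Measured compounds:
Compound 1, `CC[C@H](C)[C@H](N)CN(C(=O)[C@@H]1C[C@H]1c1ccc(OC)cc1)c1ccc(-c2ccccc2)cc1`: > 25000 nM in a functional assay for agonist activity at G protein-coupled receptor 88 (Homo sapiens), read by HTRF and cAMP accumulation; on this read-out lower numbers stand for an effect already at smaller amounts and higher numbers for an effect only at larger amounts of compound
Compound 2, `COc1cccc(-c2ccc(N(C[C@@H](N)CC(C)C)C(=O)[C@@H]3C[C@H]3c3ccccc3)cc2)c1`: 1100 nM in this assay
Compound 3, `CC[C@H](C)[C@H](N)CN(C(=O)[C@@H]1C[C@H]1c1ccccc1)c1ccc(-c2ccc(C(C)(C)C)cc2)cc1`: 750 nM in this assay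

Compound 1 reaches only the limit of this assay, (the limit of > 25000 nM in this assay, at which 1 of the 3 values shown sits), and no number is given for it. Compound 3 has the lowest of the two numbers shown, and compound 2 sits close to it, within the usual scatter of this assay, so no order can be drawn between these two.

The unmeasured compound 4, `CC[C@H](C)[C@H](N)CN(C(=O)[C@@H]1C[C@H]1c1ccccc1)c1ccc(-c2ccc(NS(C)(=O)=O)cc2)cc1`, is built from compound 3 by one change: methanesulfonamido in place of tert-butyl on an aromatic carbon. No measured pair in this set follows a change of this kind, so the size of the step cannot be read from the data shown. Within this small set, a step from compound 3 to compound 4 that goes somewhat beyond the scatter, towards an effect only at larger amounts, is expected. Compound 4 is expected to give 2000 nM in this assay, with a range from 500 nM to 8000 nM. That estimate means an expected step of a 2.7-fold higher number from compound 3 to compound 4 (0.43 log units; beyond the scatter).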

Compound 4, half-maximal effective concentration: 1200 nM
Estimate against measurement, compound 4: 1.7-fold (0.22 log units) above, within the range that was stated.
By their numbers in this assay, from the lowest: compounds 3, 2 and 4 (each within the scatter of the next). At a limit, above all of these: compound 1.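

Among these compounds, the earlier compounds offered no step between measured pairs, so this is the first direct reading of this position, on an aromatic carbon para to a large group. In this assay the exchange gives a 1.6-fold higher number from compound 3 to compound 4 (0.20 log units; within the scatter), which leaves the two compounds indistinguishable even though tert-butyl, with no hydrogen-bond donor or acceptor, gives way to methanesulfonamido, which carries both. Nothing measured here offers a reason for this result.

Going by these compounds, it remains open whether the same holds for other groups at this place, such as an amine, a carboxylic acid or a longer chain. Also open, on these data alone, is whether the amide-like hydrogen of methanesulfonamido matters, which a methyl group on its nitrogen would test, and whether the exchange reads the same on the other compounds' cores.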